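Ester Chain Changes and Calcium Channel Inhibition

The source may hold more compounds than are shown below. What is called first, only, known or untested is meant among the compounds shown, and "the series" means these compounds.

Compound 1 `COC(=O)C1=C(C)NC(C)=C(C(=O)OCc2ccc(F)c(F)c2)C1c1cccc([N+](=O)[O-])c1`: 20 nM
Compound 2 `COC(=O)C1=C(C)NC(C)=C(C(=O)OC2Cc3ccccc3C2)C1c1cccc([N+](=O)[O-])c1`: 43 nM
Compound 3 `COC(=O)C1=C(C)NC(C)=C(C(=O)OCCC(C)c2ccccc2)C1c1cccc([N+](=O)[O-])c1`: 11 nM

In a functional assay on HEK293 cells for antagonist activity at Voltage-dependent L-type calcium channel subunit alpha-1D (Rattus norvegicus), read by FLIPR (a higher number here means a weaker inhibitor, a lower number a stronger inhibitor), compound 3 gives the lowest number of the three; its gap to compound 1 is within the scatter, whereas a 3.9-fold lower number from compound 2 to compound 3 (0.59 log units; beyond the scatter) lies beyond it. Compound 4 `COC(=O)C1=C(C)NC(C)=C(C(=O)OCCC(c2ccccc2)c2ccccc2)C1c1cccc([N+](=O)[O-])c1` differs from compound 3 by phenyl in place of methyl on a saturated chain carbon bound to an aromatic carbon and a saturated chain carbon. Within the data shown here, no measured step touches this chain carbon directly; the nearest comparisons are a 1.8-fold lower number from compound 1 to compound 3 (0.26 log units; within the scatter) and a 3.9-fold lower number from compound 2 to compound 3 (0.59 log units; beyond the scatter), both modest changes on the ester side. A step of similar or smaller size is therefore expected in this assay, most likely none beyond the scatter, so that a 1.4-fold higher number from compound 3 to compound 4 (0.13 log units; within the scatter) is anticipated. Compound 4 is accordingly expected to give 15 nM, with a range from 5 nM to 45 nM.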

Compound 4, half-maximal inhibitory concentration: 270 nM
Estimate against measurement, compound 4: 18-fold (1.26 log units) below, outside the stated range (above it).
By their numbers in this assay, from the lowest: compounds 3 and 1 (each within the scatter of the next); then compound 2; then compound 4.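

In this assay, the saturated chain carbon bound to an aromatic carbon and a saturated chain carbon proves sensitive: phenyl in place of methyl gives a 25-fold higher number from compound 3 to compound 4 (1.39 log units; beyond the scatter), the only large step among these compounds. The ester side chain therefore does not accept every aromatic addition, although the earlier changes there gave only modest steps. No measurement shown here accounts for this step. The compounds shown leave open whether ethyl or a cyclohexyl ring at this carbon would keep the number close to that of compound 3, or would also raise it.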